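Fluorophenyl placement in a two-compound cytotoxicity series

The compounds below may be only part of what the source reports. "The series", "measured", "known", "first", "only" and "open" are said of these compounds alone.

Of the compounds shown here, two have been measured in a functional assay on HeLa cells (Homo sapiens) for cytotoxicity, read by MTT assay, with a stated time of 48 h; a higher number here means a weaker inhibitor, a lower number a stronger inhibitor. Compound 1 `O=C(/C=C/c1ccccc1F)Nc1ccc(CC2=CC(=O)OC2)cc1` gives 45800 nM in this assay. Compound 2 `C=C1OC(=O)C=C1Cc1ccc(NC(=O)/C=C/c2ccc(F)cc2)cc1` gives 2770 nM in this assay. Compound 2 stands lowest of the two numbers; its nearest neighbour is compound 1, whose number lies higher by a margin beyond the scatter. Among the compounds with values here, compound 1 and compound 2 differ from each other in more than one place, so no single step links them and only their two values can be set side by side.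

Compound 3 `C=C1OC(=O)C=C1Cc1ccc(NC(=O)/C=C/c2ccccc2F)cc1` has not yet been measured. It differs from compound 2 in one place: 2-fluorophenyl in place of 4-fluorophenyl on a double-bonded chain carbon bound to a double-bonded chain carbon. Compound 1 also carries a 2-fluorophenyl, on a different core, and its value in this assay is the higher of the two; this is the only pointer available and it does not isolate the fluorophenyl change. The step in this assay is expected to be upward, of a size that may reach beyond the scatter, with wide uncertainty: a 2.2-fold higher number from compound 2 to compound 3 (0.34 log units; beyond the scatter). Compound 3 is estimated at 6000 nM in this assay, within a range from 1500 nM to 25000 nM.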

Compound 3, half-maximal inhibitory concentration: 6930 nM
Compound 3: middle estimate off by 1.2-fold (0.06 log units), on the low side; the range from low to high includes it.
By their numbers in this assay, from the lowest: compound 2; then compound 3; then compound 1.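

On the shared core, in this assay, 2-fluorophenyl in place of 4-fluorophenyl on a double-bonded chain carbon bound to a double-bonded chain carbon gives a 2.5-fold higher number from compound 2 to compound 3 (0.40 log units; beyond the scatter), so the result at this position depends on where the fluorine sits on the phenyl ring, even with the same atoms in the group. With 2-fluorophenyl held constant, the ring group of compound 3 in place of that of compound 1 gives a 6.6-fold lower number from compound 1 to compound 3 (0.82 log units; beyond the scatter), and these two single-place steps now link compound 1 and compound 2, whose gap could not be divided before, with each change on that path running toward a lower number. No measurement offered here explains either step.

Still open, as far as these compounds go, is how a 3-fluorophenyl, an unsubstituted phenyl or a 4-methoxyphenyl would read at this position, and whether the ring-group step holds when 4-fluorophenyl replaces 2-fluorophenyl. These numbers also come from HeLa cells alone, so they say nothing about how the compounds behave in non-cancerous cells or in any other cell line.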